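The source may report more compounds than this note shows. Statements on the series, on what has been measured and on what is new or still open speak of the compounds shown alone.

Three compounds share one core and differ only in the substituted phenyl group on a nitrogen on an aromatic ring. Compound 1 `CN1CCN(CCCOc2cccc3nc(Nc4ccc(Cl)c(C(F)(F)F)c4)ccc23)CC1` carries a 4-chloro-3-(trifluoromethyl)phenyl group; in a functional assay on cells (Panel ovarian (Carcinoma cell lines), Homo sapiens) for inhibition, read by sulforhodamine B assay, with a stated time of 48 h (a lower number here means a stronger inhibitor of growth, a higher number a weaker inhibitor of growth), compound 1 gives 4180 nM. Compound 2 `CN1CCN(CCCOc2cccc3nc(Nc4ccc(Cl)c(F)c4)ccc23)CC1` carries a 4-chloro-3-fluorophenyl group, and in this assay compound 2 gives 4870 nM. Compound 3 `CN1CCN(CCCOc2cccc3nc(Nc4cc(Cl)cc(Cl)c4)ccc23)CC1` carries a 3,5-dichlorophenyl group, and in this assay compound 3 gives 4100 nM. For the measured compounds named here, of these three numbers, compound 3 has the lowest, yet all three sit close together: a 1.2-fold higher number from compound 1 to compound 2 (0.07 log units; within the scatter), a 1.0-fold lower number from compound 1 to compound 3 (0.01 log units; within the scatter) and a 1.2-fold lower number from compound 2 to compound 3 (0.07 log units; within the scatter), each within the scatter, so no compound can be called stronger than another here.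

Compound 4 `CN1CCN(CCCOc2cccc3nc(Nc4cccc(Cl)c4)ccc23)CC1` has not yet been measured. It differs from compound 3 in one place: hydrogen in place of chloro on an aromatic carbon. Going by the values given here, none of the measured steps removes a substituent outright; each only exchanges one substituted phenyl for another, and none of those exchanges moved the number beyond the scatter. The step from compound 3 to compound 4 is therefore expected to be small, if anything a slightly higher number, estimated as a 1.2-fold higher number from compound 3 to compound 4 (0.09 log units; within the scatter). For compound 4 in this assay the estimate is 5000 nM, expected to fall between 2500 nM and 10000 nM.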

Compound 4, concentration for total growth inhibition: 4310 nM
Beside the measured number, compound 4's estimate is 1.2-fold (0.06 log units) above it; measured number inside the range.
By their numbers in this assay, from the lowest: compounds 3, 1, 4 and 2 (each within the scatter of the next).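

In this assay, for the compounds shown here, the swap of 3,5-dichlorophenyl for 3-chlorophenyl gives a 1.1-fold higher number from compound 3 to compound 4 (0.02 log units; within the scatter), and this is the first step that takes a substituent away instead of exchanging one substituted phenyl for another. The two further comparisons point the same way, with a 1.1-fold lower number from compound 2 to compound 4 (0.05 log units; within the scatter) and a 1.0-fold higher number from compound 1 to compound 4 (0.01 log units; within the scatter), so a phenyl group with a single chloro cannot be told apart from the three more heavily substituted phenyl groups. Among these four compounds, then, neither the second chloro of compound 3, nor the fluoro of compound 2, nor the trifluoromethyl of compound 1 is needed to keep the number where it is, and no measurement shown accounts for how close the numbers lie.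

Still open, as far as these compounds go, is whether any group on this phenyl matters at all, since a phenyl with no chloro, or one with an amine or a carboxylic acid in place of the remaining chloro, could yet give a step beyond the scatter. From the compounds shown here alone, the shared core and its chain also stay untested here, so nothing shows whether a longer chain would matter more than the phenyl group does.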